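Nitro for methoxy on the sulfonyl aryl, second occurrence

The source may hold more compounds than are shown below. What is called first, only, known or untested is meant among the compounds shown, and "the series" means these compounds.

Measured compounds:
compound 1 `COc1ccc(Cc2nnc(NC(=O)/C(C#N)=C/c3ccccc3OS(=O)(=O)c3ccc(OC)cc3)s2)cc1` — 30%
compound 2 `COc1ccc(Cc2nnc(NC(=O)/C(C#N)=C/c3ccccc3OS(=O)(=O)c3ccc([N+](=O)[O-])cc3)s2)cc1` — 17%
compound 3 `COc1ccc(S(=O)(=O)Oc2ccccc2/C=C(\C#N)C(=O)Nc2nnc(Cc3cccc4ccccc34)s2)cc1` — 29%

In an ADME assay on HEK-293T cells (Homo sapiens) for inhibition, read by CCK-8 assay, with a stated time of 48 h, tested at 20 uM (a higher number here means more inhibition of growth at the concentration tested, a lower number less inhibition of growth), compound 1 gives 30%. The change nitro in place of methoxy on an aromatic carbon produced a number 13 percentage points lower from compound 1 to compound 2 (beyond the scatter). The change naphthalen-1-yl in place of 4-methoxyphenyl on a saturated chain carbon bound to an aromatic carbon produced a number 1 percentage points lower from compound 1 to compound 3 (within the scatter), so compound 1 and compound 3 cannot be told apart.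

Compound 4 `N#C/C(=C\c1ccccc1OS(=O)(=O)c1ccc([N+](=O)[O-])cc1)C(=O)Nc1nnc(Cc2cccc3ccccc23)s1` has not been measured. It differs from compound 3 by nitro in place of methoxy on an aromatic carbon, the same change as from compound 1 to compound 2, at the same place on the same core difference (naphthalen-1-yl in place of 4-methoxyphenyl on a saturated chain carbon bound to an aromatic carbon). The expectation rests on one earlier step only, a number 13 percentage points lower from compound 1 to compound 2 (beyond the scatter), so the estimate for compound 4 is a step of a number 12 percentage points lower from compound 3 to compound 4 (beyond the scatter) in this assay. Compound 4 is thus expected at 17%, between 7% and 27%.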

Compound 4, percent growth inhibition at one concentration: 25%
Estimate against measurement, compound 4: 8 percentage points below; the range from low to high includes it.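

In this assay, nitro in place of methoxy gives a number 4 percentage points lower from compound 3 to compound 4 (within the scatter), so no loss is resolved in the naphthalen-1-yl pair, while naphthalen-1-yl in place of 4-methoxyphenyl gives a number 8 percentage points higher from compound 2 to compound 4 (within the scatter). The two nitro steps cannot be told apart, but this does not establish a shared drop, as only one of them lies beyond the scatter: the same change on two cores in this assay, a number 13 percentage points lower (beyond the scatter) from compound 1 to compound 2 and a number 4 percentage points lower (within the scatter) from compound 3 to compound 4, 9 percentage points apart, within the scatter of two such steps. The naphthalen-1-yl change likewise reads the same in both pairs, without a resolved effect in either: the same change on two cores in this assay, a number 1 percentage points lower (within the scatter) from compound 1 to compound 3 and a number 8 percentage points higher (within the scatter) from compound 2 to compound 4, 9 percentage points apart, within the scatter of two such steps.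

Still open, on these data alone, is how an amine or a carboxylic acid would read in place of methoxy on the phenylsulfonyl group. Also open, as far as these compounds go, is the effect of a longer chain in place of the single saturated carbon carrying the 4-methoxyphenyl or naphthalen-1-yl group.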